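The source may hold more compounds than are shown below. What is called first, only, known or untested is meant among the compounds shown, and "the series" means these compounds.

Two compounds have been tested so far in a functional assay on HT-29 cells (Homo sapiens) for inhibition, read by sulforhodamine B assay, with a stated time of 72 h (on this read-out higher numbers stand for weaker inhibition and lower numbers for stronger inhibition), with these results:

- Compound 1 `COc1cc2c(Nc3ccc(F)c(Cl)c3)ncnc2cc1OCCCn1ccnc1[N+](=O)[O-]` gives 6140 nM
- Compound 2 `COc1cc2c(Nc3cccc(Br)c3)ncnc2cc1OCCCn1ccnc1[N+](=O)[O-]` gives 10900 nM

Among the compounds with values here, on these numbers, compound 2 cannot be told apart from the only other measured compound. Within the data shown here, the one measured step is a 1.8-fold higher number from compound 1 to compound 2 (0.25 log units; within the scatter) and it lies within the scatter. That step changes the group on the nitrogen and leaves the chain alone, so it bears only indirectly on what follows.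

Compound 3 `COc1cc2c(Nc3cccc(Br)c3)ncnc2cc1OCCCCCn1ccnc1[N+](=O)[O-]` differs from compound 2 in one place: 2-(2-nitro-1H-imidazol-1-yl)ethyl in place of 2-nitro-1H-imidazol-1-yl on a saturated chain carbon, three bonds along the chain from an oxygen on an aromatic ring that is, 2-(2-nitro-1H-imidazol-1-yl)ethyl in place of 2-nitro-1H-imidazol-1-yl on a saturated chain carbon, three bonds along the chain from an oxygen on an aromatic ring.

Among the measured compounds shown here, no measured step tests a change of this kind, so the data suggest no direction. The expectation therefore starts from compound 2 at 10900 nM and foresees no shift beyond the scatter, with a wide margin. The expected step is a 1.2-fold lower number from compound 2 to compound 3 (0.08 log units; within the scatter) and this is only an estimate. For compound 3 the estimated value is 9000 nM with an expected range from 3500 nM to 23000 nM in this assay.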

Compound 3, half-maximal inhibitory concentration: 5050 nM
For compound 3 the middle estimate is 1.8-fold (0.25 log units) above the measured one, and the stated range covers the measured number.
By their numbers in this assay, from the lowest: compounds 3, 1 and 2 (each within the scatter of the next, the first and the last beyond it).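

Moving the nitroimidazole further out, with 2-(2-nitro-1H-imidazol-1-yl)ethyl in place of 2-nitro-1H-imidazol-1-yl, gives a 2.2-fold lower number from compound 2 to compound 3 (0.33 log units; beyond the scatter) in this assay, a modest shift towards stronger inhibition. This is the first look at the chain among the compounds shown, and it indicates that the position on a saturated chain carbon, three bonds along the chain from an oxygen on an aromatic ring, can take this extension with no loss of inhibition, whereas the one earlier step, at the group on the nitrogen, stayed within the scatter. The data shown offer no measurement that could explain why the longer chain goes with the lower number.

One pair cannot show whether the number keeps falling as the chain grows, so a longer chain or a shorter one would be needed to tell a steady trend from a single favourable length. As far as these compounds go, it also remains open whether the same extension has a similar effect with the 3-chloro-4-fluorophenyl group on the nitrogen, and whether an amine at the end of the chain could stand in for the 2-nitro-1H-imidazol-1-yl group.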